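The compounds below may be only part of what the source reports. "The series", "measured", "known", "first", "only" and "open" are said of these compounds alone.

Measured so far:
- compound 1 `CC(=O)c1ccc(OCC(O)CN2CCCCC2)cc1`: 75900 nM
- compound 2 `CC(C)N(CC(O)COc1ccccc1C(=O)CCc1cccc2ccccc12)C(C)C`: 540 nM
- compound 3 `O=C(CCc1cccc2ccccc12)c1ccccc1OCC(O)CNCCC(c1ccccc1)c1ccccc1`: 720 nM

In a functional assay on CCRF-CEM/VCR-1000 cells (Homo sapiens) for inhibition (on this read-out lower numbers stand for stronger inhibition and higher numbers for weaker inhibition), compound 1 gives the highest of the three numbers; compound 3 and compound 2 both sit far lower, well beyond the scatter. For the measured compounds named here, compound 4 `O=C(CCc1ccccc1)c1ccc(OCC(O)CN2CCCCC2)cc1` differs from compound 1 by benzyl in place of hydrogen on a saturated chain carbon bound to a carbonyl carbon; no measured pair shows this change alone. Compound 2 and compound 3 both carry an extended chain on the ketone and both give low numbers in this assay, but they also differ from compound 1 in the amine and in the ring substitution, so their values cannot be read as the effect of the ketone chain alone. A moderate step downward from compound 1 to compound 4, a 9.5-fold lower number from compound 1 to compound 4 (0.98 log units; beyond the scatter), is expected. For compound 4 the estimate is 8000 nM, between 2000 nM and 30000 nM.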

Compound 4, half-maximal inhibitory concentration: 1360 nM
Compound 4: middle estimate off by 5.9-fold (0.77 log units), on the high side, and the stated range ends above it.
By their numbers in this assay, from the lowest: compounds 2, 3 and 4 (each within the scatter of the next, the first and the last beyond it); then compound 1.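

In this assay, benzyl in place of hydrogen on a saturated chain carbon bound to a carbonyl carbon gives a 56-fold lower number from compound 1 to compound 4 (1.75 log units; beyond the scatter), so this one change on the core of compound 1 carries a large step. Compound 2 and compound 3 differ from compound 1 in more than one place and could not isolate this effect. No measured evidence bears on the reason for the step.

Open, on these data alone, is how the number responds at this position to an ethyl group, a longer chain or a chain ending in an amine. Also open, as far as these compounds go, is whether a carboxylic acid on the added ring keeps the step.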